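The compounds below may be only part of what the source reports. "The series", "measured", "known", "first", "only" and "open" are said of these compounds alone.

Of the compounds shown here, three with a shared core have been measured in a functional assay on HT-1080 cells (Homo sapiens) for cytotoxicity, read by MTT assay, with a stated time of 72 h; on this read-out lower numbers stand for stronger inhibition and higher numbers for weaker inhibition. Compound 1 `COc1ccc(Cn2nc(-c3ccccc3)c3cc(C(=N)Nc4ccccc4)nc(NC4CCCCC4)c32)cc1` gives 3400 nM. Compound 2 `N=C(Nc1ccccc1)c1cc2c(-c3ccccc3)n[nH]c2c(NC2CCCCC2)n1` gives 850 nM, and compound 3 `COc1ccc(Cn2cc3cc(C(=N)Nc4ccccc4)ncc3n2)cc1` gives 1130 nM. Among compounds that differ in a single place, only one step is known: a 4.0-fold lower number from compound 1 to compound 2 (0.60 log units; beyond the scatter). On the numbers shown, compound 3 stands second highest of the three; its nearest neighbour is compound 2, whose value lies within the scatter of its own, while compound 1, the furthest, sits higher by a margin beyond the scatter.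

Compound 4 `COc1ccc(Cn2cc3cc(C(=N)Nc4cccc(C(F)(F)F)c4)ncc3n2)cc1` has not yet been measured. It differs from compound 3 in one respect: trifluoromethyl in place of hydrogen on an aromatic carbon. Among the measured compounds shown here, no measured step bears on this change; the one step available concerns the aromatic nitrogen of the core and says nothing about a substituent on the six-membered aromatic ring of carbon only. With nothing to point either way, compound 4 is expected to stay close to compound 3, and the estimated step is a 1.1-fold lower number from compound 3 to compound 4 (0.05 log units; within the scatter) in this assay, not beyond the scatter. Compound 4 is therefore estimated at 1000 nM in this assay, with a range from 400 nM to 2800 nM.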

Compound 4, half-maximal inhibitory concentration: 13000 nM
Compound 4: the middle estimate sits 13-fold (1.11 log units) below what was measured; measured number outside the range, above it.
By their numbers in this assay, from the lowest: compounds 2 and 3 (each within the scatter of the next); then compound 1; then compound 4.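

In this assay, among the compounds shown here, the change from phenyl to 3-(trifluoromethyl)phenyl gives a 12-fold higher number from compound 3 to compound 4 (1.06 log units; beyond the scatter), which shows that this six-membered aromatic ring of carbon only, untouched in the earlier compounds, does not accept every substituent without consequence. For the compounds shown here, the step points towards weaker inhibition and is larger than the only earlier step, a 4.0-fold lower number from compound 1 to compound 2 (0.60 log units; beyond the scatter), which points the other way and concerns the aromatic nitrogen of the core, so the outer phenyl now stands as the place with the larger known effect on this read-out. The compounds shown offer no measurement that accounts for this loss.

As far as these compounds go, it remains open whether the loss belongs to trifluoromethyl in particular or to any group in this place, a question that a methyl, a methoxy, an amine or a carboxylic acid on the same ring would help to settle. From the compounds shown here alone, it is equally open whether the same change would give a step of similar size on the core of compound 2, which carries further groups.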